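The compounds below may be only part of what the source reports. "The series", "measured", "known", "first", "only" and "open" are said of these compounds alone.

The measured compounds:
compound 1, `COc1cc(-c2cc(/C=C/C(=O)c3ccc(N)cc3)[nH]n2)cc(OC)c1OC`, giving 69%
compound 2, `COc1cc(-c2cc(/C=C/C(=O)c3ccc(Cl)c(Cl)c3)[nH]n2)cc(OC)c1OC`, giving 88%
compound 3, `COc1ccc(C(=O)/C=C/c2cc(-c3cc(OC)c(OC)c(OC)c3)n[nH]2)cc1OC`, giving 67%

All three share one core and differ only in the aryl group attached to the carbonyl carbon. In a functional assay on SF-539 cells (Homo sapiens) for cytotoxicity, read by sulforhodamine B assay, with a stated time of 48 h, tested at 1 uM (on this read-out higher numbers stand for a weaker effect at the one concentration tested and lower numbers for a stronger effect), compound 3 gives the lowest number of the three, but its gap to compound 1 is small: the step of a number 2 percentage points lower from compound 1 to compound 3 (within the scatter) lies within the scatter, so these two cannot be ranked against each other. Only compound 2 stands clearly apart, as a number 21 percentage points lower from compound 2 to compound 3 (beyond the scatter) and a number 19 percentage points higher from compound 1 to compound 2 (beyond the scatter) show.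

Compound 4, `COc1ccc(C(=O)/C=C/c2cc(-c3cc(OC)c(OC)c(OC)c3)n[nH]2)cc1`, has not yet been measured. Relative to compound 3 the change is hydrogen in place of methoxy on an aromatic carbon, so that 3,4-dimethoxyphenyl becomes 4-methoxyphenyl. Among the compounds with values here, no measured step removes a methoxy from this ring; the measured steps only exchange whole aryl groups on the carbonyl carbon, and even those gave at most modest shifts. Since a number 2 percentage points lower from compound 1 to compound 3 (within the scatter) shows that one such swap left the number essentially unchanged, the loss of a single methoxy is expected to move the read-out little, if anything slightly upward. Compound 4 is therefore estimated at 72%, with a range from 58% to 88%. The expected step of a number 5 percentage points higher from compound 3 to compound 4 (within the scatter) is estimated to stay within the scatter.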

Compound 4, a percentage reported as activity, at one concentration (the size of the read-out at that concentration, not a potency): 87%
For compound 4 the middle estimate is 15 percentage points below the measured one, and the stated range covers the measured number.
By their numbers in this assay, from the lowest: compounds 3 and 1 (each within the scatter of the next); then compounds 4 and 2 (each within the scatter of the next).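

The methoxy that compound 3 has and compound 4 lacks turns out to matter on its own: in this assay, a number 20 percentage points higher from compound 3 to compound 4 (beyond the scatter), so removing this one group, and not only exchanging a whole aryl group, can shift the read-out beyond the scatter. Within the data shown here, the step of a number 1 percentage points lower from compound 2 to compound 4 (within the scatter) places 4-methoxyphenyl level with 3,4-dichlorophenyl, while a number 18 percentage points higher from compound 1 to compound 4 (beyond the scatter) separates it from 4-aminophenyl, so the single methoxy of compound 4 does not match the amino group of compound 1 in this assay, although the 3,4-dimethoxyphenyl of compound 3 does. No measurement is available that would explain why this methoxy makes a difference.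

The compounds shown leave open whether the stronger effect needs a methoxy on that aromatic carbon specifically, or whether a hydroxy group, a fluorine atom or an ethoxy group there would serve as well. As far as these compounds go, each number also describes a single concentration, so these compounds can be compared only by whether their effect is stronger or weaker at that concentration, and how they would compare at any other concentration remains unknown.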